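A few compounds are considered here, and "the series" means these few. Any claim that something is new, unique, unknown or untested is made for them only; others in the source may bear on it.

The pair measured so far in a functional assay on HeLa cells (Homo sapiens) for antiproliferative activity, read by CCK-8 assay, with a stated time of 72 h, tested at 2 uM (on this read-out higher numbers stand for a stronger effect at the one concentration tested and lower numbers for a weaker effect), consists of compound 1 `Nc1ccccc1NC(=O)c1ccc(CSC(=S)N2CCN(c3ccc(Cl)cc3)CC2)cc1` and compound 2 `CC1CCN(C(=S)SCc2ccc(C(=O)Nc3ccccc3N)cc2)CC1`. In this assay compound 1 gives 51.2%, and compound 2 gives 46.8%; the two numbers lie within the scatter of each other, so neither stands apart from the other. Compound 3 `Nc1ccccc1NC(=O)c1ccc(CSC(=S)N2CCN(c3ccncc3)CC2)cc1` has not yet been measured. It differs from compound 1 by pyridin-4-yl in place of 4-chlorophenyl on an amine nitrogen in a ring. Among the measured compounds shown here, with no step between measured compounds to lean on, only a small shift is expected in this assay, likely a slight decrease not beyond the scatter, as a number 6.2 percentage points lower from compound 1 to compound 3 (within the scatter). Compound 3 is therefore estimated to reach 45%, within a range from 30% to 60%.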

Compound 3, a percentage reported as inhibition, at one concentration (the size of the read-out at that concentration, not a potency): 77%
Beside the measured number, compound 3's estimate is 32 percentage points below it; measured number above the stated range.
By their numbers in this assay, from the lowest: compounds 2 and 1 (each within the scatter of the next); then compound 3.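

At this place, on an amine nitrogen in a ring, the choice of aromatic group clearly moves the read-out in this assay: pyridin-4-yl in place of 4-chlorophenyl gives a number 25.8 percentage points higher from compound 1 to compound 3 (beyond the scatter), beyond the scatter. Among the compounds shown here, the earlier compounds offered no single-place step, so this is the first sign that the position responds to change. Nothing shown here explains the rise. Going by these compounds, it remains open whether a pyridin-3-yl or an unsubstituted phenyl group would give a similar step, and so whether the rise follows the ring nitrogen or the loss of the chlorine.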